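Cytotoxicity notes on the oxalamide piperidine series

A few compounds are considered here, and "the series" means these few. Any claim that something is new, unique, unknown or untested is made for them only; others in the source may bear on it.

The series shares an oxalamide linked to a halogenated anilide; the readout is an ADME assay on MT2 cells (Homo sapiens) for cytotoxicity, read by XTT assay, with a stated time of 4 days; on this read-out higher numbers stand for lower toxicity in this test and lower numbers for higher toxicity in this test. Compound 1 `CCn1cc(NC(=O)C(=O)Nc2ccc(Cl)cc2)cn1` gives 10700 nM in this assay. Compound 2 `Cc1nc(C(NC(=O)C(=O)Nc2ccc(Cl)cc2)C2CCCCN2C)sc1CCO` gives 88000 nM in this assay. Compound 3 `Cc1nc(C(NC(=O)C(=O)Nc2ccc(F)cc2F)C2CCCCN2)sc1CO` reaches only the limit of > 110000 nM in this assay, a limit and not a number (the limit of > 110000 nM in this assay, at which 1 of the 3 values shown sits). Among the two numbers shown, compound 2 stands highest, with compound 1 the nearer value and the gap between them beyond the scatter.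

Compound 4 `Cc1nc(C(NC(=O)C(=O)Nc2ccc(Cl)cc2)C2CCCCN2)sc1CCO` is not yet measured in this assay. It differs from compound 2 by hydrogen in place of methyl on an amine nitrogen in a ring. Compound 2 already sits at the high end of the numbers shown, and compound 3, which also carries the unsubstituted piperidine ring, reaches only the limit. Compound 4 is therefore expected to show no shift beyond the scatter, with a step of a 1.1-fold higher number from compound 2 to compound 4 (0.03 log units; within the scatter). The estimate for compound 4 in this assay is 95000 nM, with a range from 40000 nM to 220000 nM.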

Compound 4, half-maximal cytotoxic concentration: > 62000 nM
Compound 4: only a limit was reported; the forecaster's own chance of this, stated with the estimate: 40%; the middle value does not contradict the limit.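

In this assay compound 4 gives > 62000 nM, a limit and not a number. Within the data shown here, no step from compound 2 to compound 4 can be read from it. The compounds shown leave open whether replacing 1-methylpiperidin-2-yl with piperidin-2-yl shifts this read-out beyond the scatter.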